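A few compounds are considered here, and "the series" means these few. Any claim that something is new, unique, unknown or untested is made for them only; others in the source may bear on it.

Compound 1 `COc1ccc(CNCc2c(OC)cc(Oc3cccc(Nc4ccccc4)c3)cc2OC)cc1` gives 2620 nM in a functional assay on HCT-116 cells (Homo sapiens) for inhibition, read by MTT assay, with a stated time of 72 h; a higher number here means a weaker inhibitor, a lower number a stronger inhibitor. Compound 2 `COc1cc(Oc2cccc(Nc3ccccc3)c2)cc(OC)c1CNCc1ccccc1` gives 4070 nM in this assay. Compound 3 `COc1cc(Oc2cccc(Nc3ccccc3)c2)cc(OC)c1CN[C@H](C)c1ccccc1` reaches only a limit of this assay, > 20000 nM, so no number is known for it; this is the limit of > 20000 nM in this assay, at which 1 of the 3 values shown sits.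

Compound 2 stands alongside compound 1: a 1.6-fold higher number from compound 1 to compound 2 (0.19 log units; within the scatter), so the two cannot be told apart on these numbers. The step that lowered compound 3 to its limit came from a different part of the molecule, an at least 4.9-fold higher number from compound 2 to compound 3 (0.69 log units; beyond the scatter) and an at least 7.6-fold higher number from compound 1 to compound 3 (0.88 log units; beyond the scatter), and does not touch the change considered here.

Compound 4 `COc1cc(Oc2cccc(Nc3ccccc3)c2)cc(OC)c1CNCc1ccc(O)cc1` is not yet measured. It differs from compound 2 by hydroxy in place of hydrogen on an aromatic carbon. For the measured compounds named here, the only measured step at this position is the one from compound 1 to compound 2, where methoxy gave way to hydrogen on the same aromatic carbon, and that step stayed within the scatter. Nothing measured here points to a step beyond the scatter in either direction for hydroxy in place of hydrogen.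

Compound 4 is therefore expected to give about 3500 nM in this assay, somewhere between 1500 nM and 8000 nM. This estimate means a 1.2-fold lower number from compound 2 to compound 4 (0.07 log units; within the scatter), a step expected to remain within the scatter.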

Compound 4, half-maximal inhibitory concentration: 3360 nM
Compound 4: middle estimate off by 1.0-fold (0.02 log units), on the high side, within the range that was stated.
By their numbers in this assay, from the lowest: compounds 1, 4 and 2 (each within the scatter of the next). At a limit, above all of these: compound 3.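

Hydroxy is now the third group seen on this aromatic carbon of the benzyl ring, para to a large group, and in this assay the change from hydrogen gives a 1.2-fold lower number from compound 2 to compound 4 (0.08 log units; within the scatter). Compared with methoxy, the loss of the methyl on the oxygen gives a 1.3-fold higher number from compound 1 to compound 4 (0.11 log units; within the scatter), so compound 1, compound 2 and compound 4 cannot be told apart, even though hydroxy brings a hydrogen-bond donor that hydrogen lacks. The step of an at least 5.9-fold lower number from compound 3 to compound 4 (0.77 log units; beyond the scatter) replaces the whole group on the amine nitrogen and therefore says nothing about hydroxy alone, and compound 3 has a limit rather than a number: the limit of > 20000 nM in this assay, at which 1 of the 4 values shown sits.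

What the compounds shown leave open is whether this carbon would accept groups of other kinds just as readily, such as an amine, a carboxylic acid or a longer chain like butoxy. They also leave open whether hydroxy would give a similar result at another carbon of the same ring, and whether a step beyond the scatter can be found at this position at all.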